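Working notes: from compound 3 to compound 4

This account rests on a few compounds, and the source may have more. Where it says the series, first, only, none or still open, it means among the compounds named here.

Values so far in a functional assay on A549 cells (Homo sapiens) for cytotoxicity, read by colorimetric assay and MTT assay; on this read-out lower numbers stand for stronger inhibition and higher numbers for weaker inhibition
- compound 1 `CCOC(=O)Cn1c(=O)c(-c2ccc(OC)cc2)cc2c(OC)cc(OC)cc21` gives 10000 nM
- compound 2 `COc1ccc(-c2cc3c(OC)cc(OC)cc3n(CC(=O)O)c2=O)cc1` gives 10000 nM
- compound 3 `COc1ccc(-c2cc3c(OC)cc(OC)cc3n(CCC#N)c2=O)cc1` gives 10000 nM

Compound 3 stands level with compounds 1 and 2 at the digits shown. The next step leads to compound 4 (`COc1ccc(-c2cc3c(OC)cc(OC)cc3n(CCC(=O)OCc3ccccc3)c2=O)cc1`) and is benzyloxycarbonyl in place of cyano on a saturated chain carbon, two bonds along the chain from an aromatic nitrogen in this form: benzyloxycarbonyl in place of cyano on a saturated chain carbon, two bonds along the chain from an aromatic nitrogen. Among the measured compounds shown here, three measured steps bear on it: no change at the digits printed from compound 1 to compound 2 (within the scatter) and no change at the digits printed from compound 1 to compound 3 (within the scatter) and no change at the digits printed from compound 2 to compound 3 (within the scatter) all stay within the scatter. For the measured compounds named here, no measured compound carries benzyloxycarbonyl, so this support is limited. No step beyond the scatter is therefore expected in this assay, and the expected step is no change at the digits printed from compound 3 to compound 4 (within the scatter) on this basis. For compound 4 the estimated value is 10000 nM with an expected range from 4000 nM to 20000 nM overall.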

Compound 4, half-maximal inhibitory concentration: 10000 nM
Compound 4: middle estimate and measured number agree at the digits printed; the measured number falls inside the stated range.
By their numbers in this assay, from the lowest: compounds 1, 2, 3 and 4 (each within the scatter of the next).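

In this assay, replacing cyano with benzyloxycarbonyl on this saturated chain carbon brings a six-membered aromatic ring into the side chain and gives no change at the digits printed from compound 3 to compound 4 (within the scatter). Against the carboxy and ethoxycarbonyl side chains, (benzyloxycarbonyl)methyl gives no change at the digits printed from compound 2 to compound 4 (within the scatter) and no change at the digits printed from compound 1 to compound 4 (within the scatter), so the level now also holds for an aromatic ring at this position. No supporting data bear on this result.

As far as these compounds go, whether an amine or an amide at this position, or a change on the shared core, would move the value stays open.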